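Working notes: fluoro added to compound 2

A few compounds are considered here, and "the series" means these few. Any claim that something is new, unique, unknown or untested is made for them only; others in the source may bear on it.

Measured in a functional assay on HCC827 cells (Homo sapiens) for antiproliferative activity, read by sulforhodamine B assay, with a stated time of 72 h (a higher number here means a weaker inhibitor, a lower number a stronger inhibitor), so far:
- compound 1 `C=C1CC(CBr)(c2ccc(F)cc2)OC1=O` gives 2300 nM
- compound 2 `C=C1CC(CI)(c2ccccc2)OC1=O` gives 2200 nM

Compound 2 stands level with compound 1, the two numbers lying within the scatter of each other. Compound 3 `C=C1CC(CI)(c2ccc(F)cc2)OC1=O` is still to be measured in this assay. It differs from compound 2 by fluoro in place of hydrogen on an aromatic carbon. Among the compounds with values here, no measured pair shows this change alone, so the data give no direct size for it. Within the data shown here, with compound 1 at 2300 nM and compound 2 at 2200 nM, the series so far offers no sign of a large move, and no step beyond the scatter is expected in either direction. The expected step is a 1.1-fold lower number from compound 2 to compound 3 (0.04 log units; within the scatter). For compound 3 the estimated value is 2000 nM, with an expected range of 800 nM to 5000 nM.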

Compound 3, half-maximal inhibitory concentration: 1100 nM
For compound 3 the middle estimate is 1.8-fold (0.26 log units) above the measured one; the range from low to high includes it.
By their numbers in this assay, from the lowest: compounds 3, 2 and 1 (each within the scatter of the next, the first and the last beyond it).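

In this assay the fluoro in place of hydrogen on the aromatic carbon now has a first size, a 2.0-fold lower number from compound 2 to compound 3 (0.30 log units; within the scatter), so this position tolerates fluoro but the step alone does not establish a gain. Within the data shown here, with fluoro held in place on the ring, iodo in place of bromo on the saturated chain carbon gives a 2.1-fold lower number from compound 1 to compound 3 (0.32 log units; beyond the scatter), the only step that clears the scatter, though it remains modest and rests on a single pair. Nothing available accounts for either step.

From the compounds shown here alone, whether fluoro gives a step of similar size when bromo sits on the chain carbon remains open, as does whether the halogen step holds without fluoro on the ring. Also open, going by these compounds, is how a chloro or an amine on that chain carbon, or a methoxy on the aromatic carbon, would read.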